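From a Triazole to a Pyrazole in Paw Edema Testing

This account rests on a few compounds, and the source may have more. Where it says the series, first, only, none or still open, it means among the compounds named here.

compound 1: `O=C(O)c1cc(-n2cncn2)ccc1O`, 200 mg/kg
compound 2: `O=C(O)c1cc(-n2ccnn2)ccc1O`, 150 mg/kg

Of the compounds shown here, two have been tested in a functional assay on the whole organism for inhibition, with Rattus norvegicus as the target, read by paw edema; a higher number here means that more compound is needed for the effect, a lower number that less compound is needed. Compound 1 gives 200 mg/kg, and compound 2 gives 150 mg/kg. Within the data shown here, the one step between them, a 1.3-fold lower number from compound 1 to compound 2 (0.12 log units; within the scatter), lies within the scatter. Compound 2 holds the lowest of the two numbers, but its nearest neighbour, compound 1, sits within the scatter of it, so no order can be claimed.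

Compound 3 `O=C(O)c1cc(-n2cccn2)ccc1O` has not yet been measured in this assay. It differs from compound 2 in one place: 1H-pyrazol-1-yl in place of 1H-1,2,3-triazol-1-yl on an aromatic carbon. Among the measured compounds shown here, the single measured step, that from compound 1 to compound 2, also exchanges one five-membered aromatic ring for another and stayed within the scatter; it bears on the present change only loosely, as no measured step goes from three hetero atoms to two. The expected step is no change at the digits printed from compound 2 to compound 3 (within the scatter), not beyond the scatter. The estimate for compound 3 is 150 mg/kg, with a range from 75 mg/kg to 300 mg/kg.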

Compound 3, dose for half-maximal effect: 200 mg/kg
The estimate for compound 3 lay 1.3-fold (0.12 log units) below the measured number; low and high end bracket the measured number.
By their numbers in this assay, from the lowest: compounds 2, 1 and 3 (each within the scatter of the next).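

In this assay, the exchange on the aromatic carbon para to the hydroxy group gives a 1.3-fold higher number from compound 2 to compound 3 (0.12 log units; within the scatter), and the exchange from the other triazole gives no change at the digits printed from compound 1 to compound 3 (within the scatter). This extends the picture at this position to a five-membered aromatic ring with 2 hetero atoms and 2 hydrogen-bond acceptors, where 1H-1,2,3-triazol-1-yl has 3 of each, and that exchange did not carry the number beyond the scatter. No evidence that could explain these numbers is available.

On these data alone, the three compounds carry only five-membered aromatic rings at this position, so it remains open whether an amine or a longer chain there would give a number beyond the scatter. Also open, as far as these compounds go, is whether replacing the carboxy group of the shared core with an amide would do so.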